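The source may hold more compounds than are shown below. What is called first, only, known or untested is meant among the compounds shown, and "the series" means these compounds.

Compound 1 `CC(C)C(=O)OCOC(=O)C1=C(S[C@@H]2CN[C@H](C(=O)Nc3cccc(C(=O)O)c3)C2)[C@H](C)[C@@H]2[C@@H]([C@@H](C)O)C(=O)N12`: 0%. Compound 2 `C[C@@H](O)[C@H]1C(=O)N2C(C(=O)OCOC(=O)OC(C)(C)C)=C(S[C@@H]3CN[C@H](C(=O)Nc4cccc(C(=O)O)c4)C3)[C@H](C)[C@H]12`: 0%. Compound 3 `C[C@@H](O)[C@H]1C(=O)N2C(C(=O)OCOC(=O)C3CCCCC3)=C(S[C@@H]3CN[C@H](C(=O)Nc4cccc(C(=O)O)c4)C3)[C@H](C)[C@H]12`: 0%.

In an ADME assay on a cell-free system (plasma, Rattus norvegicus) for metabolic stability, read by LC-MS, with a stated time of 60 min, at 37 degrees C, tested at 50 uM (on this read-out higher numbers stand for a more stable compound and lower numbers for a less stable compound), compound 3 gives 0%, level with compound 1 and compound 2 at the digits shown; the steps of no change at the digits printed from compound 1 to compound 3 (within the scatter) and no change at the digits printed from compound 2 to compound 3 (within the scatter) are within the scatter, as is no change at the digits printed from compound 1 to compound 2 (within the scatter). Compound 4 `C[C@@H](O)[C@H]1C(=O)N2C(C(=O)OCC(F)(F)F)=C(S[C@@H]3CN[C@H](C(=O)Nc4cccc(C(=O)O)c4)C3)[C@H](C)[C@H]12` differs from compound 3 by trifluoromethyl in place of (cyclohexylcarbonyl)oxy on a saturated chain carbon bound to an oxygen next to a carbonyl group. The three measured steps all exchange one group for another on a carbonyl carbon; none of them removes the (cyclohexylcarbonyl)oxy group itself, so they do not bear directly on this change. Among the measured compounds shown here, they do show that compound 3 sits at the floor of the read-out, so no downward step is possible. Compound 4 is therefore expected to stay low, at an estimated 15% with a range from 0% to 60%, an expected step of a number 15 percentage points higher from compound 3 to compound 4 (beyond the scatter).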

Compound 4, percent of the compound remaining: 7%
Beside the measured number, compound 4's estimate is 8 percentage points above it; measured number inside the range.
By their numbers in this assay, from the lowest: compounds 1, 2, 3 and 4 (each within the scatter of the next).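

Exchanging the (cyclohexylcarbonyl)oxy group for trifluoromethyl gives a number 7 percentage points higher from compound 3 to compound 4 (within the scatter), and the matching exchanges from the other two compounds give a number 7 percentage points higher from compound 2 to compound 4 (within the scatter) and a number 7 percentage points higher from compound 1 to compound 4 (within the scatter). Thus, in this assay, removing the whole group on this saturated chain carbon, rather than exchanging a group on its carbonyl carbon, leaves compound 4 within the scatter of all three earlier compounds. Nothing given here offers an explanation for this result.

From the compounds shown here alone, it remains open whether an amine, a carboxylic acid or a longer chain at this place would give a value beyond the scatter.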